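The source may hold more compounds than are shown below. What is called first, only, known or untested is meant among the compounds shown, and "the series" means these compounds.

The measured compounds:
Compound 1, `O=C(Nc1cc(Cl)cc(Cl)c1)c1cnc(O)nc1C(F)(F)F`: in an assay on Jurkat cells for inhibition of nuclear factor NF-kappa-B p105 subunit (Homo sapiens) (a lower number here means a stronger inhibitor, a higher number a weaker inhibitor), compound 1 gives > 10000 nM, which is a limit of the assay and not a number.
Compound 2, `O=C(Nc1cc(C(F)(F)F)cc(C(F)(F)F)c1)c1cnc(Cl)nc1C(F)(F)F`: in this assay compound 2 gives 50 nM.
Compound 3, `NC(=O)c1cc(NC(=O)c2cnc(Cl)nc2C(F)(F)F)cc(C(F)(F)F)c1`: in this assay compound 3 gives 5000 nM.

Among the two numbers that are not limits, compound 3 stands at the higher end, so it is the weaker of the two inhibitors. Its nearest neighbour in structure is compound 2, and the step between them is large: a 100-fold higher number from compound 2 to compound 3 (2.00 log units; beyond the scatter), where the change is carbamoyl in place of trifluoromethyl on an aromatic carbon.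

Compound 4, `CCCCNC(=O)c1cc(NC(=O)c2cnc(Cl)nc2C(F)(F)F)cc(C(F)(F)F)c1`, has not yet been measured. It differs from compound 3 by butyl in place of hydrogen on an amide-type nitrogen. No measured step touches a substituent on an amide-type nitrogen; the one step shown, a 100-fold higher number from compound 2 to compound 3 (2.00 log units; beyond the scatter), exchanges the whole carbamoyl group for a trifluoromethyl group and therefore speaks to this smaller change only indirectly. The butyl group adds four carbons without any donor or acceptor, and the shared core, the chloro-substituted heteroaryl amide, is unchanged. The expectation is a step of moderate size in this assay, most likely towards a lower number, but the direction is uncertain and the range is kept wide.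

For compound 4 the estimate in this assay is 1500 nM, between 300 nM and 8000 nM, meaning an expected step of a 3.3-fold lower number from compound 3 to compound 4 (0.52 log units; beyond the scatter).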

Compound 4, half-maximal inhibitory concentration: > 10000 nM
Compound 4: only a limit was reported; the forecaster's own chance of this, stated with the estimate: 10%; at least 6.6-fold (0.82 log units) between middle value and limit.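

In this assay compound 4 gives > 10000 nM, which is a limit of the assay and not a number. Butyl on the amide-type nitrogen wins back none of the strength lost with the carbamoyl group, and the result is an at least 2.0-fold higher number from compound 3 to compound 4 (0.30 log units; that floor lies within the scatter), but the true size of this step cannot be told because compound 4 sits at a limit: the limit of > 10000 nM in this assay, at which 2 of the 4 values shown sit. Measured against compound 2, butylcarbamoyl in place of trifluoromethyl on an aromatic carbon gives an at least 200-fold higher number from compound 2 to compound 4 (2.30 log units; beyond the scatter), so neither of the two amides shown comes near the trifluoromethyl group in this assay.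

With only hydrogen and butyl shown on this nitrogen, it remains open whether a smaller group such as methyl, or a chain ending in an amine or a carboxylic acid, would give a lower number than butyl does. On these data alone, it also remains open whether a nitrile or a methyl ester on the same aromatic carbon would stay closer to compound 2 than the two amides do.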